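Methyl for fluoro on a shared cytotoxic benzoxazole scaffold

The compounds below may be only part of what the source reports. "The series", "measured", "known", "first", "only" and "open" are said of these compounds alone.

Three compounds built on one shared core were tested in a functional assay on A549 cells (Homo sapiens) for cytotoxicity, read by MTT assay, with a stated time of 24 h; on this read-out lower numbers stand for stronger inhibition and higher numbers for weaker inhibition. Compound 3 `Cc1cc(-c2nc3cc(F)ccc3o2)ccc1NC(=O)CN1CCN(CCN(C)C)CC1` gives 7370 nM, compound 1 `Cc1ccc2oc(-c3ccc(NC(=O)CN4CCN(CCN(C)C)CC4)c(C)c3)nc2c1` gives 11000 nM, and compound 2 `Cc1cc(-c2nc3cc(F)ccc3o2)ccc1NC(=O)CN1CCN(CCCN(C)C)CC1` gives 12200 nM. Compound 1 differs from compound 3 by methyl in place of fluoro on an aromatic carbon, and that step gave a 1.5-fold higher number from compound 3 to compound 1 (0.17 log units; within the scatter). Compound 2 differs from compound 3 by (dimethylamino)methyl in place of dimethylamino on a saturated chain carbon, two bonds along the chain from an amine nitrogen in a ring, with a 1.7-fold lower number from compound 2 to compound 3 (0.22 log units; within the scatter). Compound 4 `Cc1ccc2oc(-c3ccc(NC(=O)CN4CCN(CCCN(C)C)CC4)c(C)c3)nc2c1` has not yet been measured; it differs from compound 2 by methyl in place of fluoro on an aromatic carbon, the same change as from compound 3 to compound 1, now made on the core of compound 2. Because the earlier step of a 1.5-fold higher number from compound 3 to compound 1 (0.17 log units; within the scatter) stayed within the scatter, only a small step is expected here. For compound 4 the expected step is a 1.2-fold higher number from compound 2 to compound 4 (0.09 log units; within the scatter). Compound 4 is estimated at 15000 nM, most likely between 7000 nM and 35000 nM.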

Compound 4, half-maximal inhibitory concentration: 15300 nM
Beside the measured number, compound 4's estimate is 1.0-fold (0.01 log units) below it; the measured number falls inside the stated range.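

Putting methyl in place of fluoro gave a 1.3-fold higher number from compound 2 to compound 4 (0.10 log units; within the scatter), and the change carried across the two cores with no difference that can be told apart: the same change on two cores in this assay, a 1.5-fold higher number (0.17 log units; within the scatter) from compound 3 to compound 1 and a 1.3-fold higher number (0.10 log units; within the scatter) from compound 2 to compound 4, 1.2-fold (0.08 log units) apart, within the scatter of two such steps

Putting (dimethylamino)methyl in place of dimethylamino gave a 1.4-fold higher number from compound 1 to compound 4 (0.14 log units; within the scatter), and this change also carried across: the same change on two cores in this assay, a 1.7-fold lower number (0.22 log units; within the scatter) from compound 2 to compound 3 and a 1.4-fold lower number (0.14 log units; within the scatter) from compound 4 to compound 1, 1.2-fold (0.08 log units) apart, within the scatter of two such steps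

Each change therefore looks consistent from one core to the other, but every step lies within the scatter, so these four compounds do not show that either change really moves the number, only that no sizeable effect appears on either core.

Still open, on these data alone, is whether other groups in place of fluoro, such as chloro, methoxy or a nitrile, would move the number beyond the scatter. The same question stands for a longer chain or a carboxylic acid in place of the dimethylamino end.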